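From Methylamino to Ethylamino on the Shared Core

The source may hold more compounds than are shown below. What is called first, only, known or untested is meant among the compounds shown, and "the series" means these compounds.

In a functional assay on NB1 cells (Homo sapiens) for cytotoxicity, read by MTT assay, with a stated time of 3 days (on this read-out higher numbers stand for weaker inhibition and lower numbers for stronger inhibition), compound 1 `N#Cc1c(Nc2ccccc2)nc(SCc2nc3ccccc3[nH]2)nc1-c1ccccc1` gives 2.5 nM and compound 2 `CNc1nc(SCc2nc3ccccc3[nH]2)nc(-c2ccccc2)c1C#N` gives 4.46 nM. Going by the values given here, compound 2 thus stands within the scatter of compound 1, the only other measured compound, so the two cannot be ranked on these numbers.

Compound 3 `CCNc1nc(SCc2nc3ccccc3[nH]2)nc(-c2ccccc2)c1C#N` differs from compound 2 by a single small change: methyl in place of hydrogen on a saturated chain carbon bound to a nitrogen on an aromatic ring. In words, this is methyl in place of hydrogen on a saturated chain carbon bound to a nitrogen on an aromatic ring, which turns methylamino into ethylamino.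

Among the compounds with values here, only one measured step bears on this change. With methyl in place of phenyl on a nitrogen on an aromatic ring, the data show a 1.8-fold higher number from compound 1 to compound 2 (0.25 log units; within the scatter). That exchange of groups on the nitrogen left the numbers in this assay within the scatter, and the change leading to compound 3 is a smaller one. No shift beyond the scatter is therefore expected, and no direction can be claimed. The expected step is a 1.1-fold lower number from compound 2 to compound 3 (0.05 log units; within the scatter). A single step is thin evidence, so the range is kept wide. The estimate for compound 3 is 4 nM, with an expected range from 1.8 nM to 9.5 nM.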

Compound 3, half-maximal inhibitory concentration: 2.63 nM
The estimate for compound 3 lay 1.5-fold (0.18 log units) above the measured number, within the range that was stated.
By their numbers in this assay, from the lowest: compounds 1, 3 and 2 (each within the scatter of the next).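

In this assay, the added methyl on the saturated chain carbon bound to the nitrogen gives a 1.7-fold lower number from compound 2 to compound 3 (0.23 log units; within the scatter), so lengthening methylamino to ethylamino does not separate the two compounds. Ethyl in place of phenyl on the same nitrogen gives a 1.1-fold higher number from compound 1 to compound 3 (0.02 log units; within the scatter), which is also within the scatter. The earlier pair offered only one exchange on this nitrogen, whereas phenyl, methyl and ethyl now stand within the scatter of one another, so among these three compounds neither the size of the alkyl chain nor the exchange of an alkyl chain for phenyl gives a difference that can be read. No supporting data accompany these numbers to account for this result.

The compounds shown leave open whether a longer chain such as propyl or butyl, a branched group such as isopropyl, or an unsubstituted amine on this nitrogen would also stay within the scatter of these three in this assay. They also leave open whether a chain ending in a hydroxyl group or a carboxylic acid would move the number beyond it.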